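Trimming the ester acyl group on a cyclohexyl nitroanilide

The source may report more compounds than this note shows. Statements on the series, on what has been measured and on what is new or still open speak of the compounds shown alone.

Compound 1 `O=C(OC1(C(=O)Nc2ccc([N+](=O)[O-])cc2)CCCCC1)c1ccc(C(F)(F)F)cc1` gives 26 nM in a functional assay on NFS-60 cells (Mus musculus) for inhibition, read by MTT assay, with a stated time of 72 h; on this read-out lower numbers stand for stronger inhibition and higher numbers for weaker inhibition. Compound 2 `O=C(OC1(C(=O)Nc2ccc([N+](=O)[O-])cc2)CCCCC1)c1ccccc1` gives 766 nM in this assay, the highest of the two numbers shown; the change a 29-fold higher number from compound 1 to compound 2 (1.47 log units; beyond the scatter) was large. Compound 3 `CC(=O)OC1(C(=O)Nc2ccc([N+](=O)[O-])cc2)CCCCC1` differs from compound 2 by methyl in place of phenyl on a carbonyl carbon. Going by the values given here, the one measured step concerns the same benzoyl group and was large, so a further weakening beyond the scatter is expected for compound 3, though its size is uncertain. Compound 3 is estimated at 3000 nM (range 800 nM to 15000 nM), a step of a 3.9-fold higher number from compound 2 to compound 3 (0.59 log units; beyond the scatter).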

Compound 3, half-maximal inhibitory concentration: 517 nM
Compound 3: middle estimate off by 5.8-fold (0.76 log units), on the high side, outside the stated range (below it).
By their numbers in this assay, from the lowest: compound 1; then compounds 3 and 2 (each within the scatter of the next).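

Phenyl and methyl on this carbonyl carbon are not told apart, with a 1.5-fold lower number from compound 2 to compound 3 (0.17 log units; within the scatter). The phenyl ring without trifluoromethyl therefore brings no gain beyond the scatter, while the 4-(trifluoromethyl)phenyl group stands well apart from methyl, with a 20-fold higher number from compound 1 to compound 3 (1.30 log units; beyond the scatter). Nothing available bears on the reason for this.

From the compounds shown here alone, it remains open whether a chlorine or methoxy group on the phenyl ring would give a similar gain to trifluoromethyl. Going by these compounds, it is also open whether a longer chain, such as butanoyl, would behave like acetyl.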